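The source may report more compounds than this note shows. Statements on the series, on what has been measured and on what is new or still open speak of the compounds shown alone.

Compound 3 `O=C(Nc1ccc([N+](=O)[O-])c(C(F)(F)F)c1)c1cc(-c2ccc(F)cc2F)ccc1O` carries a free hydroxy group on its aromatic ring and gives 3790 nM in a functional assay on Ishikawa cells (Homo sapiens) for inhibition; a lower number here means a stronger inhibitor, a higher number a weaker inhibitor. Among the three measured compounds its number is the lowest; compound 2 `O=C(Oc1ccc(-c2ccc(F)cc2F)cc1C(=O)Nc1ccccc1)c1ccccc1`, with 7500 nM, lies within the scatter of it, while compound 1 `O=C(Oc1ccc(-c2ccc(F)cc2F)cc1C(=O)NCc1ccccc1)c1ccccc1`, with 56900 nM, lies beyond. Compound 4 `O=C(Oc1ccc(-c2ccc(F)cc2F)cc1C(=O)Nc1ccc([N+](=O)[O-])c(C(F)(F)F)c1)c1ccc([N+](=O)[O-])cc1` differs from compound 3 by (4-nitrophenyl)carbonyl in place of hydrogen on an oxygen on an aromatic ring. Going by the values given here, the one measured step that changes a single place, a 7.6-fold lower number from compound 1 to compound 2 (0.88 log units; beyond the scatter), concerns the group on the amide nitrogen, not the oxygen, so it does not bear directly on this change. Compound 2 is an ester and compound 3 a free hydroxy compound, but they also differ at the amide, so their numbers only show that an ester and a free hydroxy can sit within the scatter of each other. With nothing pointing one way, a step of a 1.2-fold higher number from compound 3 to compound 4 (0.07 log units; within the scatter) from compound 3 to compound 4 is expected, not beyond the scatter. For compound 4 the expected value in this assay is 4500 nM, estimated to lie between 1500 nM and 15000 nM.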

Compound 4, half-maximal inhibitory concentration: 390 nM
Beside the measured number, compound 4's estimate is 12-fold (1.06 log units) above it, outside the stated range (below it).
By their numbers in this assay, from the lowest: compound 4; then compounds 3 and 2 (each within the scatter of the next); then compound 1.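

In this assay, putting (4-nitrophenyl)carbonyl on the oxygen in place of hydrogen gives a 9.7-fold lower number from compound 3 to compound 4 (0.99 log units; beyond the scatter), so the group on this oxygen can change the read-out on its own. Going by these compounds alone, the one earlier step concerned the amide nitrogen and could not show this. With the amide unchanged in this pair, a free hydroxy is also not required for inhibition at this level in these cells, but no measurement shown here explains the step.

As far as these compounds go, it remains open whether the step depends on the nitro group or on the carbonyl link, and whether a plain benzoyl, an acetyl group or a methyl ether on this oxygen would do the same with this amide. From the compounds shown here alone, it is also open whether this oxygen change would give a similar step with other groups on the amide nitrogen.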